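The source may hold more compounds than are shown below. What is called first, only, known or untested is meant among the compounds shown, and "the series" means these compounds.

In a functional assay on HeLa cells (Homo sapiens) for cytotoxicity, read by MTT assay, with a stated time of 24 h (on this read-out higher numbers stand for weaker inhibition and lower numbers for stronger inhibition), compound 2 (`COc1ccc(/C=C(\C#N)C(=O)N/N=C(\C)c2c(O)c3ccc(O)cc3oc2=O)cc1OC`) gives 13500 nM and so stands level, within the scatter, with its two measured relatives. These are compound 1 (`COc1cc(/C=C(\C#N)C(=O)N/N=C(\C)c2c(O)c3ccc(O)cc3oc2=O)ccc1O`) at 10500 nM and compound 3 (`C/C(=N\NC(=O)/C(C#N)=C/c1ccc([N+](=O)[O-])cc1)c1c(O)c2ccc(O)cc2oc1=O`) at 8360 nM on the same shared core. Compound 4 (`C/C(=N\NC(=O)/C(C#N)=C/c1ccccc1Cl)c1c(O)c2ccc(O)cc2oc1=O`) has not yet been measured. It carries 2-chlorophenyl in place of 3,4-dimethoxyphenyl on a double-bonded chain carbon bound to a double-bonded chain carbon. Changing that same place with 4-nitrophenyl gave a 1.6-fold lower number from compound 2 to compound 3 (0.21 log units; within the scatter) and a 1.3-fold lower number from compound 1 to compound 3 (0.10 log units; within the scatter) while methyl in place of hydrogen on an oxygen on an aromatic ring gave a 1.3-fold higher number from compound 1 to compound 2 (0.11 log units; within the scatter) in this assay as well. Within the data shown here, no measured compound carries 2-chlorophenyl, so that group is untested here. Since all of these steps stayed within the scatter, no step beyond the scatter is expected in this assay for this change. The expected step is a 1.4-fold lower number from compound 2 to compound 4 (0.13 log units; within the scatter) and it remains an estimate. For compound 4 the estimated value is 10000 nM (5000 nM to 20000 nM).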

Compound 4, half-maximal inhibitory concentration: 11800 nM
For compound 4 the middle estimate is 1.2-fold (0.07 log units) below the measured one; the measured number falls inside the stated range.
By their numbers in this assay, from the lowest: compounds 3, 1, 4 and 2 (each within the scatter of the next).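

In this assay the change from 3,4-dimethoxyphenyl to 2-chlorophenyl on the double-bonded chain carbon gives a 1.1-fold lower number from compound 2 to compound 4 (0.06 log units; within the scatter) even though the entering group has fewer heavy atoms, carries chlorine and has no hydrogen-bond acceptors. The comparisons with the other two aryl groups read the same way, with a 1.4-fold higher number from compound 3 to compound 4 (0.15 log units; within the scatter) and a 1.1-fold higher number from compound 1 to compound 4 (0.05 log units; within the scatter) at this position, so the four compounds shown, whose groups here bear chlorine, nitro, methoxy or hydroxy substituents, stay level within the scatter. No measured evidence is available to explain this levelness.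

All four compounds keep a six-membered aromatic ring of carbon only at this place. From the compounds shown here alone, whether a pyridine ring, a saturated chain such as cyclohexyl, or a phenyl ring bearing an amine or a carboxylic acid would stay within the scatter remains open.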